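Restoring the Benzoyl Group to an Inactive Thymidine Analogue

The compounds below may be only part of what the source reports. "The series", "measured", "known", "first", "only" and "open" are said of these compounds alone.

Compound 3 `CC(=O)NC1=CS(=O)(=O)O[C@@]12[C@@H](CO[Si](C)(C)C(C)(C)C)O[C@@H](n1cc(C)c(=O)n(C)c1=O)[C@@H]2O[Si](C)(C)C(C)(C)C` reaches only a limit in a functional assay on HEL cells (Homo sapiens) (on this read-out lower numbers stand for higher toxicity in this test and higher numbers for lower toxicity in this test), giving > 200000 nM. Compound 2 `COC(=O)C(=O)CNC1=CS(=O)(=O)O[C@@]12[C@@H](CO[Si](C)(C)C(C)(C)C)O[C@@H](n1cc(C)c(=O)n(C)c1=O)[C@@H]2O[Si](C)(C)C(C)(C)C` likewise shows only a limit there, > 200000 nM. Compound 1 `Cc1cn([C@@H]2O[C@H](CO[Si](C)(C)C(C)(C)C)[C@@]3(OS(=O)(=O)C=C3NC(=O)c3ccccc3)[C@H]2O[Si](C)(C)C(C)(C)C)c(=O)n(C)c1=O` gives a real number in this assay, namely 9700 nM. The step of an at least 20-fold higher number from compound 1 to compound 3 (1.31 log units; beyond the scatter) shows that methyl in place of phenyl on the carbonyl carbon pushed toxicity out of the measurable range, and an at least 20-fold higher number from compound 1 to compound 2 (1.31 log units; beyond the scatter) points the same way; a step that the two limits leave unreadable from compound 2 to compound 3 cannot be read since both values sit at the limit of > 200000 nM in this assay, at which 2 of the 3 values shown sit. Compound 4 `Cc1cn([C@@H]2O[C@H](CO[Si](C)(C)C(C)(C)C)[C@@]3(OS(=O)(=O)C=C3NC(=O)NC(=O)c3ccccc3)[C@H]2O[Si](C)(C)C(C)(C)C)c(=O)n(C)c1=O` carries the change (benzamido in place of methyl on a carbonyl carbon), so acetyl becomes benzoylcarbamoyl and a benzoyl group returns. Because an at least 20-fold higher number from compound 1 to compound 3 (1.31 log units; beyond the scatter) was large, the step of an at least 6.6-fold lower number from compound 3 to compound 4 (0.82 log units; beyond the scatter) is expected to be a drop back into measurable toxicity. Compound 4 is therefore estimated at 30000 nM, within 8000 nM to 200000 nM.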

Compound 4, half-maximal cytotoxic concentration: >= 200000 nM
Compound 4: no number, only a limit; the forecaster's own chance of this, stated with the estimate: 35%; middle value at least 6.6-fold (0.82 log units) away from the limit.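

With benzamido in place of methyl on the carbonyl carbon, a benzoyl group is back in the molecule, yet in this assay compound 4 gives only a limit and no number: the limit of >= 200000 nM in this assay, at which 1 of the 4 values shown sits. Within the data shown here, the one readable step is an at least 20-fold higher number from compound 1 to compound 4 (1.31 log units; beyond the scatter), so a benzoyl group held further out does not bring back the value of compound 1. The steps among compounds 2, 3 and 4 cannot be read. Open, from the compounds shown here alone, is whether a phenylacetyl or a propanoyl group on the amine nitrogen would give a number in this assay.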